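A few compounds are considered here, and "the series" means these few. Any claim that something is new, unique, unknown or untested is made for them only; others in the source may bear on it.

In a functional assay on HCT-15 cells (Homo sapiens) for cytotoxicity, read by CCK-8 assay and cell counting, with a stated time of 2 days (on this read-out lower numbers stand for stronger inhibition and higher numbers for weaker inhibition), two compounds have been measured so far. Compound 1 `Oc1ccc(-c2cc(-c3ccccc3)nc(-c3ccccc3Cl)c2)cc1` gives 4990 nM in this assay. Compound 2 `Oc1cccc(-c2cc(-c3ccsc3)nc(-c3cccc(Cl)c3)c2)c1` gives 2510 nM in this assay and differs from compound 1 in more than one place. The gap between these two numbers lies within the usual scatter of repeated measurements, so the two cannot be told apart.

Compound 3 `Oc1ccc(-c2cc(-c3ccsc3)nc(-c3ccccc3Cl)c2)cc1` is built from compound 1 by a single change: thiophen-3-yl in place of phenyl on an aromatic carbon. Within the data shown here, no pair of measured compounds differs in only one place, so nothing shows directly how large such a step is here. Among the measured compounds shown here, the only hint comes from compound 2, which also carries a thiophen-3-yl group and gives 2510 nM, but its other differences from compound 1 make that hint weak. A step of a 1.2-fold lower number from compound 1 to compound 3 (0.10 log units; within the scatter) is expected, small and not beyond the scatter. For compound 3 the expected value is 4000 nM, with a range from 1500 nM to 10000 nM.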

Compound 3, half-maximal inhibitory concentration: 5830 nM
Beside the measured number, compound 3's estimate is 1.5-fold (0.16 log units) below it; the range from low to high includes it.
By their numbers in this assay, from the lowest: compounds 2, 1 and 3 (each within the scatter of the next, the first and the last beyond it).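

Putting thiophen-3-yl in place of phenyl on the aromatic carbon next to the ring nitrogen gives a 1.2-fold higher number from compound 1 to compound 3 (0.07 log units; within the scatter) in this assay. Among these compounds, this is the first direct reading of a single change here: with the 2-chlorophenyl and 4-hydroxyphenyl groups kept, a five-membered aromatic ring containing sulfur can take the place of the six-membered carbon ring with no difference this read-out can separate from the scatter. No measured property of either group bears on this result, so no explanation can be offered.

Going by these compounds, it remains open whether a group of a different kind at this position, such as an amine, a carboxylic acid or a longer alkyl chain, would move the number beyond the scatter. On these data alone, it is also open whether the same swap would give a similar result if the 2-chlorophenyl or 4-hydroxyphenyl group were replaced.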